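A few compounds are considered here, and "the series" means these few. Any claim that something is new, unique, unknown or untested is made for them only; others in the source may bear on it.

In an ADME assay on PBMC cells (Homo sapiens) for cytotoxicity, with a stated time of 5 days (on this read-out lower numbers stand for stronger inhibition and higher numbers for weaker inhibition), compound 1 `COc1nc(NC2CC2)c2ncn([C@H]3C[C@H](N=[N+]=[N-])[C@@H](CO)O3)c2n1` reaches only a limit, > 100000 nM, as the limit of > 100000 nM in this assay, at which 1 of the 2 values shown sits, records. For the measured compounds named here, compound 2 `[N-]=[N+]=N[C@H]1C[C@H](n2cnc3c(NC4CC4)nc(Cl)nc32)O[C@@H]1CO` gives 35300 nM, the only actual number so far. Chloro in place of methoxy on an aromatic carbon accounts for the single measured step, an at least 2.8-fold lower number from compound 1 to compound 2 (0.45 log units; beyond the scatter), which is at least modest and lies beyond the scatter.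

Compound 3 `CNc1nc(Cl)nc2c1ncn2[C@H]1C[C@H](N=[N+]=[N-])[C@@H](CO)O1` keeps the chloro of compound 2 and changes elsewhere: methyl in place of cyclopropyl on a nitrogen on an aromatic ring. Going by the values given here, the measured step sits at another place, so it gives no direct guide to this change, and no measured pair varies that nitrogen. In this assay, no shift beyond the scatter is therefore expected. The expected step is a 1.3-fold higher number from compound 2 to compound 3 (0.11 log units; within the scatter). For compound 3 the estimated value is 45000 nM. The expected range for compound 3 runs from 15000 nM to 100000 nM.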

Compound 3, half-maximal inhibitory concentration: > 100000 nM
Compound 3 ended at the assay's limit; the forecaster's own chance of this, stated with the estimate: 30%; middle value at least 2.2-fold (0.34 log units) away from the limit.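

For the compounds shown here, on the nitrogen on an aromatic ring, where no earlier pair offered a comparison, cyclopropylamino to methylamino gives an at least 2.8-fold higher number from compound 2 to compound 3 (0.45 log units; beyond the scatter) in this assay. This position therefore matters in this read-out, as the place carrying the chloro already did. Compound 3, like compound 1, stands at a limit and not at a number: the limit of > 100000 nM in this assay, at which 2 of the 3 values shown sit.

Compound 2 thus remains the only compound with an actual number, and each of the two single changes shown leads from it to that limit, so the size of neither change is known beyond its printed bound. Open, from the compounds shown here alone, is how an ethyl, a cyclobutyl or a plain amino group on this nitrogen would read, and whether a bromo or a fluoro at the place of the chloro would keep a measurable number.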